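The compounds below may be only part of what the source reports. "The series", "measured", "known", "first", "only" and "open" are said of these compounds alone.

Working notes on the series. Compound 1, `CN(Cc1cncnc1)S(=O)(=O)c1ccccc1Nc1cc(-c2ccc3ccn(C)c3c2)c2nccnc2c1`, gives in an assay on lysate for inhibition of 6-phosphofructo-2-kinase/fructose-2,6-bisphosphatase 3 (Homo sapiens), with stated times of 0.5 min and 45 min (a higher number here means a weaker inhibitor, a lower number a stronger inhibitor), only a limit, > 100000 nM. Going by the values given here, compound 2, `Cn1ccc2ccc(-c3cc(Nc4cnccc4C(=O)NC4CCNC(=O)C4)cc4nccnc34)cc21`, is the one member with a measured number; in this assay compound 2 gives 56500 nM. That number is the only one shown, the other value being a limit (the limit of > 100000 nM in this assay, at which 1 of the 2 values shown sits). Compound 3, `CC(=O)N1CC(NC(=O)c2ccncc2Nc2cc(-c3ccc4ccn(C)c4c3)c3nccnc3c2)C1`, differs from compound 2 at one place: 1-acetylazetidin-3-yl in place of 2-oxopiperidin-4-yl on an amide-type nitrogen, the two having the same atoms joined differently, a six-membered ring exchanged for a four-membered one. Among the compounds with values here, no step between measured compounds is available to rate this change, so its size rests on expectation alone. The step from compound 2 to compound 3 in this assay is expected to be small, a 1.3-fold higher number from compound 2 to compound 3 (0.12 log units; within the scatter), leaning toward a weaker inhibitor. Compound 3 is accordingly estimated at 75000 nM, within 25000 nM to 220000 nM, with a fair chance that only a limit is reported.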

Compound 3, half-maximal inhibitory concentration: 97400 nM
Estimate against measurement, compound 3: 1.3-fold (0.11 log units) below; measured number inside the range.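

In this assay, going by these compounds alone, the first step that can be read at this position is a 1.7-fold higher number from compound 2 to compound 3 (0.24 log units; within the scatter), for 1-acetylazetidin-3-yl in place of 2-oxopiperidin-4-yl on an amide-type nitrogen. Six-membered ring to four-membered ring, and 1 hydrogen-bond donor to 0 hydrogen-bond donors in this group, therefore leave the two numbers within the scatter of each other, and neither difference can be separated from the other in this single pair. Compound 1 gives a limit and not a number: the limit of > 100000 nM in this assay, at which 1 of the 3 values shown sits.

On these data alone, whether an amine or a carboxylic acid on this amide-type nitrogen would move the number in this assay beyond the scatter remains open. A single pair also leaves open whether any change at this position can do so.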